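Adding Two Methyl Groups to the Urea Phenyl Ring

This account rests on a few compounds, and the source may have more. Where it says the series, first, only, none or still open, it means among the compounds named here.

Of the compounds shown here, three sharing one core have been measured in a functional assay on PC-3 cells (Homo sapiens) for inhibition, with a stated time of 72 h; on this read-out lower numbers stand for stronger inhibition and higher numbers for weaker inhibition. Compound 1 `Cc1cc(Cl)ccc1NC(=O)Nc1nc(Sc2c[nH]c3ccccc23)cc(N2CCN(Cc3ccccc3)CC2)n1` gives 22500 nM. Compound 2 `COc1ccc(NC(=O)Nc2nc(Sc3c[nH]c4ccccc34)cc(N3CCN(c4ccccn4)CC3)n2)cc1` gives 33400 nM. Compound 3 `O=C(Nc1ccccc1)Nc1nc(Sc2c[nH]c3ccccc23)cc(N2CCN(Cc3ccccc3)CC2)n1` gives 42500 nM, the highest of the three numbers, though its gaps to compound 2 and to compound 1 both lie within the scatter. For the measured compounds named here, the one single-point comparison known is a 1.9-fold higher number from compound 1 to compound 3 (0.28 log units; within the scatter), and it stays within the scatter.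

Compound 4 `Cc1ccc(C)c(NC(=O)Nc2nc(Sc3c[nH]c4ccccc34)cc(N3CCN(Cc4ccccc4)CC3)n2)c1` is the next step from compound 3: 2,5-dimethylphenyl in place of phenyl on an amide-type nitrogen. Going by the values given here, only the step from compound 1 to compound 3 bears on this change, since it also swaps a substituted phenyl for a bare one on the same nitrogen, and it moved the number only a little. Returning methyl groups to that ring is therefore expected to shift the number by about as much, if at all, towards a lower value. Compound 4 is estimated to give 28000 nM, with a range from 10000 nM to 75000 nM, which means an expected step of a 1.5-fold lower number from compound 3 to compound 4 (0.18 log units; within the scatter).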

Compound 4, half-maximal inhibitory concentration: 17300 nM
Compound 4: the middle estimate sits 1.6-fold (0.21 log units) above what was measured; measured number inside the range.
By their numbers in this assay, from the lowest: compounds 4, 1, 2 and 3 (each within the scatter of the next, the first and the last beyond it).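

In this assay, putting 2,5-dimethylphenyl in place of phenyl on the amide-type nitrogen gives a 2.5-fold lower number from compound 3 to compound 4 (0.39 log units; beyond the scatter), so this position has now produced a single change that clears the usual scatter, although the step is modest. Comparing the two substituted rings tells them apart far less well: 2,5-dimethylphenyl in place of 4-chloro-2-methylphenyl gives a 1.3-fold lower number from compound 1 to compound 4 (0.11 log units; within the scatter), which means that this swap of substituents shows no real difference. Nothing measured here accounts for the step from the bare ring to the dimethyl ring.

From the compounds shown here alone, it remains open whether a single methyl group would be enough, and whether an amine or a carboxylic acid on this ring would move the number further. Going by these compounds, it is also open whether the step would hold with other groups elsewhere on the shared core.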